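Branching at the amine and a cyclohexyl extension

A few compounds are considered here, and "the series" means these few. Any claim that something is new, unique, unknown or untested is made for them only; others in the source may bear on it.

Compound 3 `CCC(CO)NCc1nc2c(OCC3CCCCC3)cccc2[nH]1` stands highest of the three measured compounds in an assay on cells for inhibition of interleukin-5 receptor subunit alpha (Mus musculus), read by WST assay, with a stated time of 48 h, tested at 30 uM, in the presence of a further agent that is not named here (a lower number here means less inhibition, a higher number more inhibition at the concentration tested (going by the name of the read-out)), giving 94.3%. Compound 1 `OCCCCNCc1nc2c(OCC3CCCCC3)cccc2[nH]1` gives 44.3% and compound 2 `OCCCCCNCc1nc2c(OCC3CCCCC3)cccc2[nH]1` gives 23.7%. The steps to compound 3 are both large: a number 50 percentage points higher from compound 1 to compound 3 (beyond the scatter) and a number 70.6 percentage points higher from compound 2 to compound 3 (beyond the scatter). Between the two linear chains, lengthening costs a modest amount: a number 20.6 percentage points lower from compound 1 to compound 2 (beyond the scatter).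

Compound 4 `OCC(CC1CCCCC1)NCc1nc2c(OCC3CCCCC3)cccc2[nH]1` keeps the branched amine substituent of compound 3 and carries cyclohexyl in place of methyl on a saturated chain carbon, two bonds along the chain from an amine nitrogen. Among the compounds with values here, no measured step changes this position; the measured steps only show that the branched substituent of compound 3 stands well above both linear chains, and that adding chain length in compound 2 lowered the read-out relative to compound 1. Within the data shown here, the change into compound 4 adds bulk at the branch rather than chain length, so none of the measured steps bears directly on it, and the expectation is for a step not beyond the scatter, with compound 3 already near the top of the read-out, so any movement is expected to be downward: a number 8.3 percentage points lower from compound 3 to compound 4 (within the scatter). Compound 4 is thus estimated at 86%, within 55% to 100%.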

Compound 4, a percentage reported as inhibition, at one concentration (the size of the read-out at that concentration, not a potency): 94.7%
Compound 4: middle estimate off by 8.7 percentage points, on the low side, within the range that was stated.
By their numbers in this assay, from the lowest: compound 2; then compound 1; then compounds 3 and 4 (each within the scatter of the next).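

In this assay, cyclohexyl in place of methyl on a saturated chain carbon, two bonds along the chain from an amine nitrogen, gives a number 0.4 percentage points higher from compound 3 to compound 4 (within the scatter). The earlier compounds shown here compared the branched substituent only with linear chains; this pair shows that the branch can carry a six-membered non-aromatic ring of carbon while compound 4 remains level with compound 3, high in the read-out. Nothing available here accounts for this result.

Open, from the compounds shown here alone, is whether a phenyl group or an aminomethyl group at this position would hold the read-out at the same level. Also open, going by these compounds, is whether the hydroxymethyl group is needed on the branch, or whether a methoxymethyl group or a carboxylic acid could stand in its place.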